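A few compounds are considered here, and "the series" means these few. Any claim that something is new, unique, unknown or untested is made for them only; others in the source may bear on it.

Of the compounds shown here, two have been measured so far in a functional assay on a cell-free system (Platelet, plasma, Homo sapiens) for inhibition; on this read-out higher numbers stand for weaker inhibition and lower numbers for stronger inhibition. Compound 1 `Cc1ccc(N(CCN2CCC(OCC(=O)O)CC2)C(=O)c2cccc(C(F)(F)F)c2)cc1` gives 20000 nM, and compound 2 `COc1cccc(C(=O)N(CCN2CCC(OCC(=O)O)CC2)c2ccc(Cl)cc2)c1` gives 74 nM. Compound 2 holds the lower number of the two, by a margin well beyond the usual scatter of repeat measurements, so it is the stronger inhibitor of the pair. Among the compounds with values here, no two measured compounds differ in one place only, so no single change has yet been seen on its own.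

Compound 3 `O=C(O)COC1CCN(CCN(C(=O)c2cccc(C(F)(F)F)c2)c2ccc(Cl)cc2)CC1` is reached from compound 2 by one change, trifluoromethyl in place of methoxy on an aromatic carbon, meta to a large group. Within the data shown here, the only hint comes from compound 1, which also carries a trifluoromethyl and gives 20000 nM, but it also departs from compound 2 elsewhere, so the hint is weak. A move toward weaker inhibition is expected, beyond the scatter but well short of the whole gap between the two measured compounds. The expected step is a 6.8-fold higher number from compound 2 to compound 3 (0.83 log units; beyond the scatter). For compound 3 the estimated value is 500 nM, with an expected range of 100 nM to 4000 nM.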

Compound 3, half-maximal inhibitory concentration: > 10000 nM
Compound 3 gave a limit, no number; the forecaster's own chance of this, stated with the estimate: 5%; middle value at least 20-fold (1.30 log units) away from the limit.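

In this assay compound 3 gives > 10000 nM, which is a limit and not a number. With the rest of the molecule unchanged, going from 3-methoxyphenyl to 3-(trifluoromethyl)phenyl brings an at least 130-fold higher number from compound 2 to compound 3 (2.13 log units; beyond the scatter), so this one change at this position is enough to lose most of the inhibition seen in compound 2, something the earlier pair could not show, as compound 1 and compound 2 differ in more than one place. The true step may be larger still, and the step for chloro in place of methyl on an aromatic carbon, linking compound 1 and compound 3, cannot be read at all, because one end of it is a limit: the limit of > 10000 nM in this assay, at which 1 of the 3 values shown sits.

Within the data shown here, with only two groups seen at this position, it remains open whether the loss comes from removing methoxy or from introducing trifluoromethyl, and a plain hydrogen, a hydroxyl or an ethoxy group there would help to separate the two. Going by these compounds, the effect of chloro in place of methyl also stays unknown, as does whether it would matter in a compound that keeps the methoxy group.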